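Notes on the step from compound 2 to compound 3

This account rests on a few compounds, and the source may have more. Where it says the series, first, only, none or still open, it means among the compounds named here.

- compound 1 `CC/C=C\C/C=C\C/C=C\C/C=C\C/C=C\C/C=C\CCC(=O)Oc1ccccc1` gives > 25000 nM (a limit of the assay, not a number)
- compound 2 `CC/C=C\C/C=C\C/C=C\C/C=C\C/C=C\C/C=C\CCC(=O)Oc1ccccc1C(C)C` gives 8200 nM

Among the compounds with values here, in a functional assay on MDA-MB-231 cells (Homo sapiens) for inhibition, read by WST assay, with a stated time of 48 h (a lower number here means a stronger inhibitor, a higher number a weaker inhibitor), compound 2 (8200 nM) carries the only actual number so far. Compound 3 `CC/C=C\C/C=C\C/C=C\C/C=C\C/C=C\C/C=C\CCC(=O)Oc1ccccc1C1CCCCC1` differs from it by cyclohexyl in place of isopropyl on an aromatic carbon. Within the data shown here, the one measured step bearing on this is an at least 3.0-fold lower number from compound 1 to compound 2 (0.48 log units; beyond the scatter) (isopropyl in place of hydrogen on an aromatic carbon). A further small lowering in this assay is therefore expected, probably not beyond the scatter, with the expected step being a 1.6-fold lower number from compound 2 to compound 3 (0.21 log units; within the scatter) here. The estimate for compound 3 is 5000 nM (range 2000 nM to 15000 nM).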

Compound 3, half-maximal inhibitory concentration: 8400 nM
Beside the measured number, compound 3's estimate is 1.7-fold (0.23 log units) below it; measured number inside the range.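

In this assay, cyclohexyl in place of isopropyl on this aromatic carbon gives a 1.0-fold higher number from compound 2 to compound 3 (0.01 log units; within the scatter), so compound 2 and compound 3 cannot be told apart and this position accepts either group. Cyclohexyl in place of hydrogen gives an at least 2.9-fold lower number from compound 1 to compound 3 (0.47 log units; beyond the scatter), so a second group at this position now stands apart from hydrogen. Compound 1 gives only a limit of the assay, so the full size of that step cannot be read: the limit of > 25000 nM in this assay, at which 1 of the 3 values shown sits.

Open, as far as these compounds go, is whether a methyl group, an amine or a carboxylic acid on this aromatic carbon would match compound 2 and compound 3.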